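The source may hold more compounds than are shown below. What is called first, only, known or untested is meant among the compounds shown, and "the series" means these compounds.

Measured compounds:
Compound 1, `COc1cc2c(cc1N1C[C@@H](C)N(C)[C@@H](C)C1)N(C(=O)Nc1cccc(Cl)c1F)CC2`: 0.1
Compound 2, `COc1cc2c(cc1N1C[C@@H](C)N(C)[C@@H](C)C1)N(C(=O)c1ccc(-c3ccccc3C)cc1)CC2`: 0

In an assay on isolated protein with 5-hydroxytryptamine receptor 1B (Homo sapiens) as the target (on this read-out lower numbers stand for smaller maximal responses and higher numbers for larger maximal responses), compound 1 gives 0.1. Compound 2, in this assay, gives 0, and the two numbers lie within the usual scatter of each other, so neither can be called larger. Both compounds share the same core and differ only in the group attached to the amide-type nitrogen.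

Compound 3, `COc1cc2c(cc1N1C[C@@H](C)N(C)[C@@H](C)C1)N(C(=O)Nc1cccc(C(F)(F)F)c1Cl)CC2`, has not yet been measured in this assay. Compared with compound 1 it carries 2-chloro-3-(trifluoromethyl)phenyl in place of 3-chloro-2-fluorophenyl on an amide-type nitrogen. The two groups are of the same kind, each a single six-membered aromatic ring of carbon only bearing halogen-containing substituents, and neither adds a hydrogen-bond donor or acceptor.

For the measured compounds named here, with no step between measured compounds to draw on, and compound 1 giving 0.1, the expectation is a step no larger than the scatter, no change at the digits printed from compound 1 to compound 3 (within the scatter). Compound 3 is therefore estimated at 0.1, within a range from 0 to 0.25.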

Compound 3, intrinsic activity: the largest response reached, as a fraction of the reference agonist's: 0
Compound 3: middle estimate off by 0.10, on the high side; the measured number falls inside the stated range.
By their numbers in this assay, from the lowest: compounds 2, 3 and 1 (each within the scatter of the next).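

With 2-chloro-3-(trifluoromethyl)phenyl in place of 3-chloro-2-fluorophenyl on the amide-type nitrogen, the result is a number 0.10 lower from compound 1 to compound 3 (within the scatter) in this assay as the read-out. This place therefore accepts a group of 11 heavy atoms instead of 8, with the chlorine and fluorine atoms differently arranged, and the maximal response of compound 3 cannot be told apart from that of compound 1. No measurement of any property of these groups accompanies the result.

The swap alters the chlorine, the fluorine and the carbon count together, so the part played by each stays unresolved. As far as these compounds go, it also remains open whether a different kind of group at this nitrogen, such as a pyridine ring, a methyl group or a chain ending in an amine, would give a larger maximal response in this assay on the same core.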